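From pyridin-4-yl to pyridin-2-yl on a shared core

The compounds below may be only part of what the source reports. "The series", "measured", "known", "first", "only" and "open" are said of these compounds alone.

Three compounds built on the same core differ only in the group carried on the ester oxygen. Compound 1 `CC1=NC(C)=C([N+](=O)[O-])C(c2ccncc2)/C1=C(\O)OC1CCCC1` gives 4250 nM in a functional assay (cardiac atrium) for agonist activity, with Cavia porcellus as the target; a higher number here means that more compound is needed for the effect, a lower number that less compound is needed. Compound 2 `CC1=NC(C)=C([N+](=O)[O-])C(c2ccncc2)/C1=C(\O)OCC(C)C` gives 8510 nM, and compound 3 `CC1=NC(C)=C([N+](=O)[O-])C(c2ccncc2)/C1=C(\O)OC(C)C` gives 8050 nM. Compound 1 holds the lowest of the three numbers, but its lead is slight: the nearest is a 1.9-fold higher number from compound 1 to compound 3 (0.28 log units; within the scatter) and the furthest is a 2.0-fold higher number from compound 1 to compound 2 (0.30 log units; within the scatter), so none of the three can be set apart from the others. Between the two open-chain esters the step is a 1.1-fold lower number from compound 2 to compound 3 (0.02 log units; within the scatter).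

Compound 4 `CC1=NC(C)=C([N+](=O)[O-])C(c2ccccn2)/C1=C(\O)OC1CCCC1` keeps the cyclopentyl ester of compound 1 and changes a different part of the molecule: pyridin-2-yl in place of pyridin-4-yl on a saturated ring carbon. Among the measured compounds shown here, none of the measured steps touches this position; all three concern the group on the ester oxygen, and all three lie within the scatter. For the measured compounds named here, there is thus no measured step that bears on the change, and no direction can be read from the data. The plain expectation is a step of no more than the scatter, a 1.4-fold higher number from compound 1 to compound 4 (0.15 log units; within the scatter), though with a wide band to reflect the unknown. Compound 4 is therefore estimated at 6000 nM, within a range from 1000 nM to 40000 nM.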

Compound 4, half-maximal effective concentration: 19800 nM
Estimate against measurement, compound 4: 3.3-fold (0.52 log units) below; low and high end bracket the measured number.
By their numbers in this assay, from the lowest: compounds 1, 3 and 2 (each within the scatter of the next); then compound 4.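

In this assay, among the compounds shown here, the exchange of pyridin-4-yl for pyridin-2-yl on a saturated ring carbon gives a 4.7-fold higher number from compound 1 to compound 4 (0.67 log units; beyond the scatter) and is the first step here to lie beyond the scatter. The earlier steps shown here all concerned the group on the ester oxygen, and none of them could be told from the scatter, so they showed nothing about this carbon. Here the cyclopentyl ester stays fixed and the two groups have the same atoms and the same counts of donors and acceptors, so the attachment of the pyridine ring alone separates compound 4 from compound 1, and no data shown here explain why the number rises with this exchange.

Going by these compounds, it remains open whether pyridin-3-yl or a plain phenyl on this carbon would stand with compound 1 or with compound 4. On these data alone, it is also open whether the same exchange would give a step of similar size on the isopropyl ester of compound 3 or the isobutyl ester of compound 2.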